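Chloro in place of (4-methoxyphenyl)(methyl)amino in compound 3

A few compounds are considered here, and "the series" means these few. Any claim that something is new, unique, unknown or untested is made for them only; others in the source may bear on it.

In a functional assay on SH-SY5Y cells (Homo sapiens) for antiproliferative activity, read by MTT assay, with a stated time of 48 h (a higher number here means a weaker inhibitor of growth, a lower number a stronger inhibitor of growth), compound 1 `COc1ccc(N(C)c2ncnc3c2ncn3Cc2cc(OC)cc(OC)c2)cc1` gives > 100000 nM, a limit
Compound 2 `COc1ccc(Cn2cnc3c(N(C)c4ccc(OC)cc4)nc(Cl)nc32)cc1` gives 31000 nM
Compound 3 `COc1ccc(N(C)c2nc(Cl)nc3c2ncn3Cc2cc(OC)cc(OC)c2)cc1` gives > 100000 nM, a limit

Compound 3 stands at the limit of > 100000 nM in this assay, at which 2 of the 3 values shown sit, so it has a limit and no number of its own. Compound 4 `COc1cc(Cn2cnc3c(Cl)nc(Cl)nc32)cc(OC)c1` differs from it by chloro in place of (4-methoxyphenyl)(methyl)amino on an aromatic carbon.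

Within the data shown here, two measured steps touch compound 3, and neither alters that group. Among the measured compounds shown here, the first is a step that the two limits leave unreadable from compound 1 to compound 3, and the two limits leave its size unreadable. The second is an at least 3.2-fold higher number from compound 2 to compound 3 (0.50 log units; beyond the scatter), which lies beyond the scatter and concerns the other end of the molecule. For the measured compounds named here, no measured step therefore sizes this replacement directly.

Compound 3 gives > 100000 nM, a limit, so any readable change in this assay can only run towards a lower number. A modest step in that direction is expected, although compound 4 may equally stay at the limit. Going by the values given here, the only number in this set, compound 2 at 31000 nM, serves as the guide for scale. The expected step is an at least 2.5-fold lower number from compound 3 to compound 4 (0.39 log units; beyond the scatter). The estimate for compound 4 is 40000 nM, with an expected range from 12000 nM to 100000 nM.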

Compound 4, concentration for 50% growth inhibition: 1700 nM
Beside the measured number, compound 4's estimate is 24-fold (1.37 log units) above it; the measured number lies below the stated range.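

In this assay, among these compounds, the exchange of (4-methoxyphenyl)(methyl)amino for chloro on this aromatic carbon brings an at least 58-fold lower number from compound 3 to compound 4 (1.76 log units; beyond the scatter), the only large step in the set. Compounds 1, 2 and 3 all carry (4-methoxyphenyl)(methyl)amino here, so they could show only what happens when the other chloro group or the methoxy pattern at the far end of the molecule changes, not how much growth inhibition depends on the group at this carbon. The step gives only a minimum for the size of the change and not its full extent, because compound 3 has a limit and no number of its own: the limit of > 100000 nM in this assay, at which 2 of the 4 values shown sit.

The compounds shown leave open whether the gain comes from chloro itself or from the departure of (4-methoxyphenyl)(methyl)amino, a question that a dimethylamino group, a methoxy group or a hydrogen on this carbon would bear on. They also leave open whether 4-methoxyphenyl in place of 3,5-dimethoxyphenyl on the saturated chain carbon would still move the number once chloro stands on this aromatic carbon.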